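The source may hold more compounds than are shown below. What is called first, only, known or untested is meant among the compounds shown, and "the series" means these compounds.

In a functional assay on RKOp27 cells (Homo sapiens) for cytotoxicity, read by MTT assay, with a stated time of 3 days (a lower number here means a stronger inhibitor, a higher number a weaker inhibitor), compound 1 (`N#Cc1c(NN)nc(SCc2nc3ccccc3[nH]2)nc1-c1ccccc1`) gives 2.55 nM while compound 2 (`N#Cc1c(Nc2ccccn2)nc(SCc2nc3ccccc3[nH]2)nc1-c1ccccc1`) gives 3.8 nM and compound 3 (`N#Cc1c(NC(N)=S)nc(SCc2nc3ccccc3[nH]2)nc1-c1ccccc1`) gives 2.63 nM on the same shared core. These three numbers lie within the scatter of one another, so compound 1 stands level with both of the others.

Compound 4 (`N#Cc1c(NC(N)=O)nc(SCc2nc3ccccc3[nH]2)nc1-c1ccccc1`) has not yet been measured. It differs from compound 1 by carbamoyl in place of amino on a nitrogen on an aromatic ring in a single place, with carbamoyl in place of amino on a nitrogen on an aromatic ring.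

Two measured steps change that same nitrogen. Compound 3, the nearest guide, carries a group holding sulfur where carbamoyl holds oxygen and shows a 1.0-fold higher number from compound 1 to compound 3 (0.01 log units; within the scatter) at that place, and compound 2, with pyridin-2-yl there, shows a 1.5-fold higher number from compound 1 to compound 2 (0.17 log units; within the scatter) as well, so no step beyond the scatter is expected in this assay in either direction. As far as these compounds go, how the oxygen-bearing group itself behaves remains untested.

In numbers, the expected change is a 1.1-fold higher number from compound 1 to compound 4 (0.04 log units; within the scatter) by this estimate. For compound 4 the estimated value is 2.8 nM with an expected range from 1.6 nM to 5 nM in this read-out.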

Compound 4, half-maximal inhibitory concentration: 2.5 nM
Estimate against measurement, compound 4: 1.1-fold (0.05 log units) above; the measured number falls inside the stated range.
By their numbers in this assay, from the lowest: compounds 4, 1, 3 and 2 (each within the scatter of the next).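

In this assay, carbamoyl in place of amino gives a 1.0-fold lower number from compound 1 to compound 4 (0.01 log units; within the scatter) and so adds another group on this nitrogen that stands level with amino. Within the data shown here, exchanging sulfur for oxygen in an otherwise identical group, a change the earlier compounds could not show, gives a 1.1-fold lower number from compound 3 to compound 4 (0.02 log units; within the scatter) and so this assay does not separate the carbonyl from its sulfur counterpart at this place. Carbamoyl in place of pyridin-2-yl gives a 1.5-fold lower number from compound 2 to compound 4 (0.18 log units; within the scatter) and so, with this result, all four compounds at this position lie within the scatter of one another, whether the group there carries a ring or not.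

Nothing available here offers a reason why these exchanges leave the number in place. As far as these compounds go, it remains open whether this level picture would hold for groups of other kinds on the same nitrogen, such as a carboxylic acid, a simple methyl, a longer chain or a larger ring, and whether any of them would bring a step beyond the scatter.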